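Methyl additions on two-nitrogen rings in a thiazole series

The source may report more compounds than this note shows. Statements on the series, on what has been measured and on what is new or still open speak of the compounds shown alone.

The shared core of compound 1 `Cc1nccn1-c1csc(Nc2cccc(Br)c2)n1` and compound 2 `Brc1ccc(Nc2nc(-n3cnc4ccccc43)cs2)cc1` is varied here by single methyl groups; the difference between the two cores is not broken down here. In a functional assay on RKO cells (Homo sapiens) for cytotoxicity, read by resazurin assay, with a stated time of 72 h (a higher number here means a weaker inhibitor, a lower number a stronger inhibitor), compound 1 gives only a limit, > 100000 nM. Compound 2 likewise gives only a limit in this assay, > 100000 nM. Compound 3 `Cc1nc2ccccc2n1-c1csc(Nc2ccc(Br)cc2)n1` carries the change methyl in place of hydrogen on an aromatic carbon and reaches 90 nM in this assay, so the step is an at least 1100-fold lower number from compound 2 to compound 3 (3.04 log units; beyond the scatter). Both of the limits sit at the limit of > 100000 nM in this assay, at which 2 of the 3 values shown sit, so the size of that step is itself only a lower bound.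

Compound 4 `Cc1cn(-c2csc(Nc3cccc(Br)c3)n2)c(C)n1` is not yet measured. It arises from compound 1 through (methyl in place of hydrogen on an aromatic carbon). Within the data shown here, this is the same kind of change as the one from compound 2 to compound 3, but not the same: there the methyl entered between two ring nitrogen atoms, next to the ring atom that bears a large group, whereas here it enters next to the ring nitrogen, two ring bonds from the ring nitrogen, two ring bonds from the ring atom that bears a large group and two ring bonds from the ring atom that bears a methyl group. Compound 1 already holds a methyl between its ring nitrogens and still shows only its limit, so the earlier gain cannot simply be carried over. The expected step for compound 4 in this assay is an at least 2.5-fold lower number from compound 1 to compound 4 (0.39 log units; beyond the scatter), which rests on the limit of compound 1, > 100000 nM, and on the different place of the incoming methyl. Compound 4 is therefore estimated at 40000 nM in this assay, with a range from 3000 nM to 150000 nM.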

Compound 4, half-maximal inhibitory concentration: > 100000 nM
Compound 4 ended at the assay's limit; the forecaster's own chance of this, stated with the estimate: 55%; at least 2.5-fold (0.39 log units) between middle value and limit.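

In this assay compound 4 gives > 100000 nM, which is a limit of the assay. The step from compound 1 to compound 4 cannot be read because compound 1 also gives only a limit: the limit of > 100000 nM in this assay, at which 3 of the 4 values shown sit. The compounds shown leave open whether this methyl changes anything in the core of compound 1, and which structural difference sets compound 3 apart from compound 4.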